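Vinyl sulfone series: pyridyl for fluorophenyl on the alkene

A few compounds are considered here, and "the series" means these few. Any claim that something is new, unique, unknown or untested is made for them only; others in the source may bear on it.

Among the compounds with values here, compound 2 `O=S(=O)(/C=C/c1ccccc1F)c1ncccc1C(F)(F)F` stands level with its one measured neighbour. In an ADME assay on BV-2 cells (Mus musculus) for cytotoxicity, with a stated time of 24 h, tested at 10 uM (on this read-out lower numbers stand for a stronger effect and higher numbers for a weaker effect at the one concentration tested), compound 2 gives 100%. The neighbour, compound 1 `O=S(=O)(/C=C/c1ccccc1F)c1ccccn1`, gives in this assay a read-out of 100%. Within the data shown here, the single measured step, no change at the digits printed from compound 1 to compound 2 (within the scatter), leaves the read-out where it was, so the series so far is flat at the top of the scale, with no sign of an effect on the cells at the concentration tested.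

Compound 3 `O=S(=O)(/C=C/c1ncccc1F)c1ncccc1C(F)(F)F` is the next compound to be measured. The change from compound 2 is 3-fluoropyridin-2-yl in place of 2-fluorophenyl on a double-bonded chain carbon bound to a double-bonded chain carbon. Among the measured compounds shown here, no measured step touches this part of the molecule; the only step on record concerns the other ring and was without change. The expectation therefore rests on that flat behaviour alone, and the step of a number 2 percentage points lower from compound 2 to compound 3 (within the scatter) is expected to stay within the scatter rather than to move in either direction. Compound 3 is thus estimated to give 98% in this assay, with a range from 85% to 110%.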

Compound 3, a percentage reported as activity, at one concentration (the size of the read-out at that concentration, not a potency): 100%
For compound 3 the middle estimate is 2 percentage points below the measured one, within the range that was stated.
By their numbers in this assay, from the lowest: compounds 1, 2 and 3 (each within the scatter of the next).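

Within the data shown here, the aryl group on a double-bonded chain carbon bound to a double-bonded chain carbon is changed here for the first time: in this assay, 3-fluoropyridin-2-yl in place of 2-fluorophenyl gives no change at the digits printed from compound 2 to compound 3 (within the scatter) in this series. The earlier step concerned only the other ring, so it could not show that this position accepts a ring with 1 hetero atom and 1 hydrogen-bond acceptor, where the leaving ring has 0 hydrogen-bond acceptors, with the read-out staying within the scatter. No available evidence bears on why the read-out holds at this position.

From the compounds shown here alone, whether it also holds for groups of another kind remains open, for instance an amine or a carboxylic acid in place of the aromatic ring at this position, or a longer chain in place of the double-bonded chain. Since the read-out comes from a single concentration, the compounds shown also leave open whether any of the three would affect the cells at a higher concentration or over a longer exposure.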